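This account rests on a few compounds, and the source may have more. Where it says the series, first, only, none or still open, it means among the compounds named here.

Compound 1 `COc1ccc(S(=O)(=O)NC(=O)NC/C=C2\CCCc3cnn(Cc4ccc(Cl)cc4Cl)c32)cc1` gives 29 nM in a functional assay on CHO-K1 cells for antagonist activity at prostaglandin E2 receptor EP3 subtype (Homo sapiens), read by TR-FRET and cAMP accumulation, with a stated time of 30 min (on this read-out lower numbers stand for stronger inhibition and higher numbers for weaker inhibition), the second highest of the three numbers recorded. Compound 3 `O=C(NS(=O)(=O)c1ccc(Cl)cc1)OC/C=C1\CCCc2cnn(Cc3ccc(Cl)cc3Cl)c21` gives 92 nM in this assay, a higher number than compound 1 by a margin beyond the scatter. Compound 2 `O=C(NC/C=C1\CCCc2cnn(C3CCN(c4ccc(F)cc4)CC3)c21)NS(=O)(=O)c1cc(Cl)c(Cl)s1` gives 6 nM, a lower number than compound 1, again beyond the scatter. Compound 4 `O=C(NC/C=C1\CCCc2cnn(Cc3ccc(Cl)cc3Cl)c21)NS(=O)(=O)c1cc(Cl)c(Cl)s1` has not been measured. It differs from compound 1 in one place: 4,5-dichlorothiophen-2-yl in place of 4-methoxyphenyl on a sulfonyl sulfur. Among the measured compounds shown here, no measured step covers this change, but the entering group is also present in compound 2, whose number is the lowest of the three. A step downward in number is therefore expected a 2.4-fold lower number from compound 1 to compound 4 (0.38 log units; beyond the scatter), beyond the scatter. Compound 4 is expected to give 12 nM, with a range from 4 nM to 35 nM.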

Compound 4, half-maximal inhibitory concentration: 11 nM
Estimate against measurement, compound 4: 1.1-fold (0.04 log units) above; the range from low to high includes it.
By their numbers in this assay, from the lowest: compounds 2 and 4 (each within the scatter of the next); then compound 1; then compound 3.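

In this assay, among the compounds shown here, putting 4,5-dichlorothiophen-2-yl in place of 4-methoxyphenyl on a sulfonyl sulfur gives a 2.6-fold lower number from compound 1 to compound 4 (0.42 log units; beyond the scatter) on an otherwise unchanged structure, the first direct reading of this change. With the group in place, compound 4 gives 11 nM and compound 2 gives 6 nM, two values within the scatter of each other despite their different substituents elsewhere. No evidence here accounts for the step. Open, on these data alone, is how a thiophen-2-yl without chlorine or a methyl group on the sulfonyl sulfur would compare.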